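Notes on the amide-aryl variation in the anilinopyrimidine series

The compounds below may be only part of what the source reports. "The series", "measured", "known", "first", "only" and "open" are said of these compounds alone.

Measured so far:
- Compound 1 `COc1ccc(C(=O)Nc2cc(Nc3nccc(-c4cn(C)c5ccccc45)n3)c(OC)cc2F)nc1`: 16800 nM
- Compound 2 `COc1cc(F)c(NC(=O)c2cnccn2)cc1Nc1nccc(-c2cn(C)c3ccccc23)n1`: 24800 nM
- Compound 3 `COc1cc(N(C)CCN(C)C)c(NC(=O)c2ccncc2)cc1Nc1nccc(-c2cn(C)c3ccccc23)n1`: 6860 nM

All three numbers come from a functional assay on NCI-H1975 cells (Homo sapiens) for antiproliferative activity, read by MTT assay, with a stated time of 72 h; a lower number here means a stronger inhibitor, a higher number a weaker inhibitor. Compound 3 holds the lowest number of the three; its gaps to compound 1 and to compound 2 both lie beyond the scatter, so on these numbers compound 3 is the strongest inhibitor of the set. Compound 4 `COc1cc(N(C)CCN(C)C)c(NC(=O)c2ccncn2)cc1Nc1nccc(-c2cn(C)c3ccccc23)n1` has not yet been measured in this assay. It differs from compound 3 in one place: pyrimidin-4-yl in place of pyridin-4-yl on a carbonyl carbon.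

Among the measured compounds shown here, only one measured step bears on this change, and only loosely. From compound 1 to compound 2 the aryl group on the carbonyl carbon also exchanged one ring atom for nitrogen, and the result was a 1.5-fold higher number from compound 1 to compound 2 (0.17 log units; within the scatter). That change also removed a methoxy group, so it is not a clean match for the step from compound 3 to compound 4, but it is the nearest comparison available.

On that basis a step of the same kind, a slightly higher number that stays within the scatter, is expected for this assay: a 1.2-fold higher number from compound 3 to compound 4 (0.09 log units; within the scatter). Compound 4 is therefore estimated at 8500 nM, with a range from 4000 nM to 18000 nM.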

Compound 4, half-maximal inhibitory concentration: 1560 nM
Estimate against measurement, compound 4: 5.4-fold (0.74 log units) above; measured number outside the range, below it.
By their numbers in this assay, from the lowest: compound 4; then compound 3; then compounds 1 and 2 (each within the scatter of the next).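

In this assay, the change from pyridin-4-yl to pyrimidin-4-yl on a carbonyl carbon gives a 4.4-fold lower number from compound 3 to compound 4 (0.64 log units; beyond the scatter), so this position, where the other neighbour of the carbonyl carbon is an amide-type nitrogen, can respond to the exchange of a single ring carbon for nitrogen. The heavy-atom count stays the same, while the count of hydrogen-bond acceptors in the group rises, and the earlier aryl change, a 1.5-fold higher number from compound 1 to compound 2 (0.17 log units; within the scatter), had shown no step beyond the scatter on this carbonyl carbon. No measurement at hand accounts for the lower number of compound 4.

The compounds shown leave open whether a pyrimidin-5-yl or a plain phenyl ring on the same carbonyl carbon would fall nearer to pyrimidin-4-yl or to pyridin-4-yl, and whether a methyl or amino group on the pyrimidin-4-yl ring would keep the number of compound 4 at 1560 nM. They also leave open whether pyrimidin-4-yl would give a step of this size on the fluorine-bearing core of compound 1 and compound 2.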